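Pyridin-2-yl for methylpyrazolyl on the benzamide of compound 3

This account rests on a few compounds, and the source may have more. Where it says the series, first, only, none or still open, it means among the compounds named here.

Compound 3 `CNC(=O)N1CCCc2ccc(NC(=O)c3ccc(-c4cnn(C)c4)cc3)cc21` stands second highest of the three numbers in a functional assay on MV4-11 cells (Homo sapiens) for antiproliferative activity, with a stated time of 6 days, tested at 6.25 uM; a lower number here means a weaker effect, a higher number a stronger effect of the compound at the concentration tested: compound 3 gives 94.4%. Its nearest neighbour is compound 1 `CNC(=O)N1CCCc2ccc(NC(=O)c3cccc(-c4ccn(C)n4)c3)cc21`, which in this assay gives 99.5%, within the scatter of compound 3. Furthest off is compound 2 `CNC(=O)N1CCCc2ccc(NC(=O)c3cccc(-c4ccccc4)c3)cc21`, which in this assay gives 1.39%, far below compound 3.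

Compound 4 `CNC(=O)N1CCCc2ccc(NC(=O)c3ccc(-c4ccccn4)cc3)cc21` differs from compound 3 in one place: pyridin-2-yl in place of 1-methyl-1H-pyrazol-4-yl on an aromatic carbon.

For the measured compounds named here, the one measured step that bears on this change is a number 98.1 percentage points lower from compound 1 to compound 2 (beyond the scatter), where the methylpyrazolyl gave way to a ring without any hetero atom and nearly all the effect was lost. Going by the values given here, compound 4 keeps one hetero atom in a six-membered ring, so the change is not the same as that step; the series holds no measured six-membered ring with one nitrogen at this position, and no pair for pyridin-2-yl in place of 1-methyl-1H-pyrazol-4-yl.

On these numbers compound 4 is expected to fall below compound 3, with the step of a number 49.4 percentage points lower from compound 3 to compound 4 (beyond the scatter) estimated to lie well beyond the scatter but smaller than the loss seen for compound 2. In this assay compound 4 is therefore estimated at 45%, with a range from 5% to 90%.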

Compound 4, a percentage reported as inhibition, at one concentration (the size of the read-out at that concentration, not a potency): 79.2%
Compound 4: middle estimate off by 34.2 percentage points, on the low side, and the stated range covers the measured number.
By their numbers in this assay, from the lowest: compound 2; then compound 4; then compounds 3 and 1 (each within the scatter of the next).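

Replacing 1-methyl-1H-pyrazol-4-yl with pyridin-2-yl in this assay gives a number 15.2 percentage points lower from compound 3 to compound 4 (beyond the scatter), a modest step, so the methylpyrazolyl is not strictly required on this aromatic carbon para to a large group. A six-membered aromatic ring with one hetero atom is tolerated at this place, with compound 4 at 79.2%, though this is a read-out at one concentration and not a potency. Nothing available accounts for the size of this step.

Still open, going by these compounds, is what phenyl would give at this same place, which would show whether the ring nitrogen of pyridin-2-yl matters here. Also open, on these data alone, is how pyridin-3-yl, pyridin-4-yl or a saturated amine such as morpholine would behave on this carbon.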